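The source may hold more compounds than are shown below. What is called first, only, known or untested is meant among the compounds shown, and "the series" means these compounds.

Measured so far in an assay on HEK-293T cells for inhibition of diacylglycerol lipase-alpha (Homo sapiens), read by colorimetric assay; a lower number here means a stronger inhibitor, a higher number a weaker inhibitor: compound 1 `O=C(CCCCc1ccccc1)c1nc2ncccc2o1`, 204 nM; compound 2 `O=C(CCCCCCCCc1ccccc1)c1nc2ncccc2o1`, 3.63 nM. Compound 3 `CCCCCC(=O)c1nc2ncccc2o1` returns no number in this assay, only the limit > 10000 nM.

Compound 3 therefore stands at the weak end of the three, on (the limit of > 10000 nM in this assay, at which 1 of the 3 values shown sits), and its distance from the other two is known only as a minimum. Among the measured compounds shown here, the one measured step that touches it, an at least 49-fold higher number from compound 1 to compound 3 (1.69 log units; beyond the scatter), is the exchange of the chain-end phenyl for methyl and says nothing about chain length as such. Compound 4 `CCCCCCCC(=O)c1nc2ncccc2o1` differs from compound 3 by ethyl in place of hydrogen on a saturated chain carbon, five bonds along the chain from a carbonyl carbon. For the measured compounds named here, no step between compound 1 and compound 2 is given; compound 1 gives 204 nM and compound 2 gives 3.63 nM, so the longer phenyl-bearing chain shows the lower number. On that basis compound 4 is expected to move downward from the limit of compound 3 by an at least 2.0-fold lower number from compound 3 to compound 4 (0.30 log units; that floor lies within the scatter), though the starting point being a limit leaves the size uncertain. Compound 4 is estimated at 5000 nM, within 1000 nM to 30000 nM.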

Compound 4, half-maximal inhibitory concentration: 631 nM
The estimate for compound 4 lay 7.9-fold (0.90 log units) above the measured number, outside the stated range (below it).
By their numbers in this assay, from the lowest: compound 2; then compound 1; then compound 4. At a limit, above all of these: compound 3.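

Ethyl in place of hydrogen, five bonds along the chain from a carbonyl carbon, gives an at least 15-fold lower number from compound 3 to compound 4 (1.19 log units; beyond the scatter), so a chain without phenyl also moves the number, which the earlier phenyl-to-methyl exchange could not show. The size of that step remains a minimum, as one end of it is a limit: the limit of > 10000 nM in this assay, at which 1 of the 4 values shown sits. Propyl in place of phenyl gives only a 3.1-fold higher number from compound 1 to compound 4 (0.49 log units; beyond the scatter), whereas hydrogen in place of benzyl gives a 170-fold higher number from compound 2 to compound 4 (2.24 log units; beyond the scatter), so a phenyl-free chain comes within a modest step of the shorter phenyl-bearing chain but stays a large step from the longer one.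

On these data alone, whether a longer chain without phenyl keeps lowering the number remains open, as does the effect of ending the chain in a carboxylic acid or an amine. With only two phenyl-bearing chain lengths shown, the course of the number between them is also unresolved.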